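The source may report more compounds than this note shows. Statements on the series, on what has been measured and on what is new or still open speak of the compounds shown alone.

Compound 1, whose structure is `COc1cc(-c2nnc(SCC(=O)Nc3ccc(/C(C)=N/O)cc3)n2-c2ccccc2)cc(OC)c1OC`, was tested in a functional assay on the whole organism (strain albino) for inhibition, with Rattus norvegicus as the target, read by paw edema, with stated times of 30 min and 2 h, at a dose of 0.28 mmol/kg by the oral route (a lower number here means less inhibition, a higher number more inhibition at the dose given (going by the name of the read-out)), where compound 1 gives 62%. Compound 2, with structure `C=CCn1c(SCC(=O)Nc2ccc(/C(C)=N/O)cc2)nnc1-c1cc(OC)c(OC)c(OC)c1`, differs from compound 1 in one place: allyl in place of phenyl on an aromatic nitrogen. In this assay compound 2 gives 53%, so the step is a number 9 percentage points lower from compound 1 to compound 2 (within the scatter).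

Compound 3, with structure `COc1cc(-c2nnc(SCC(=O)Nc3ccc(C(C)=O)cc3)n2-c2ccccc2)cc(OC)c1OC`, keeps the phenyl on the aromatic nitrogen but differs from compound 1 elsewhere: a group of 3 heavy atoms (2 carbon, 1 oxygen; no ring) in place of a group of 4 heavy atoms (2 carbon, 1 nitrogen, 1 oxygen; no ring), on an aromatic carbon. In this assay compound 3 gives 54%, a step of a number 8 percentage points lower from compound 1 to compound 3 (within the scatter).

Compound 4, with structure `C=CCn1c(SCC(=O)Nc2ccc(C(C)=O)cc2)nnc1-c1cc(OC)c(OC)c(OC)c1`, has not yet been measured. It differs from compound 3 by allyl in place of phenyl on an aromatic nitrogen. The place of this change, on the aromatic nitrogen of the five-membered ring, is described in exactly the same words as for the change from compound 1 to compound 2, so it is the same change, now made on the core of compound 3 rather than the core of compound 1.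

Going by the values given here, the one earlier instance of this change, a number 9 percentage points lower from compound 1 to compound 2 (within the scatter), was within the scatter. The step from compound 3 to compound 4 is therefore expected to be similar and small, estimated at a number 7 percentage points lower from compound 3 to compound 4 (within the scatter), resting on that single earlier step and on the value of compound 3, 54%. Compound 4 is thus expected to give about 47% in this assay, with a likely range from 35% to 58%.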

Compound 4, a percentage reported as inhibition, in the whole organism at one dose (the size of the read-out at that dose, not a potency): 54%
Compound 4: middle estimate off by 7 percentage points, on the low side; the range from low to high includes it.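

In this assay, allyl in place of phenyl on the aromatic nitrogen gives no change at the digits printed from compound 3 to compound 4 (within the scatter), and the two instances of this change agree as far as such data can tell: the same change on two cores in this assay, a number 9 percentage points lower (within the scatter) from compound 1 to compound 2 and no change at the digits printed (within the scatter) from compound 3 to compound 4, 9 percentage points apart, within the scatter of two such steps

The other change, on the aromatic carbon, where an oxime in compound 2 gives way to a carbonyl group in compound 4, gives a number 1 percentage points higher from compound 2 to compound 4 (within the scatter), and it too carries over from one core to the other without a difference beyond the scatter: the same change on two cores in this assay, a number 8 percentage points lower (within the scatter) from compound 1 to compound 3 and a number 1 percentage points higher (within the scatter) from compound 2 to compound 4, 9 percentage points apart, within the scatter of two such steps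

So in these four compounds neither change behaves differently on the second core, but every step lies within the scatter, so the data show neither that either change has a real effect on the inhibition of paw swelling nor that the steps truly add up, and two cores make no rule for the wider series.

The compounds shown leave open how other groups on the aromatic nitrogen would behave, such as a methyl, a benzyl or a longer chain. They also leave open what an amine or a carboxylic acid would do on the aromatic carbon that carries the oxime or the carbonyl group.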